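The source may hold more compounds than are shown below. What is called first, only, known or untested is meant among the compounds shown, and "the series" means these compounds.

Compound 1 `COc1cccc(CNCCCNc2ccnc3cc(Oc4ccccc4)ccc23)c1O` gives 9.28 in a physicochemical assay for acid dissociation.
Compound 2 `FC(F)(F)c1ccc(-c2ccc3c(NCCCNCc4ccco4)ccnc3c2)cc1` gives 9.47 in this assay.
Compound 3 `COc1ccc(F)cc1CNCCCNc1ccnc2cc(Oc3ccc(C(C)(C)C)cc3)ccc12` gives 9.28 in this assay.

The three measured compounds share a three-carbon chain linking two amine nitrogens, and it is the proton on such an amine that this assay follows. Compound 2 sits close to its neighbours: its number differs from compound 1 by an amount inside the usual scatter, and from compound 3 by the same small amount, so none of the three can be told apart by this measurement.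

Compound 4 `c1ccc(-c2ccc3c(NCCCNCc4ccco4)ccnc3c2)cc1` has not yet been measured. It differs from compound 2 in one place: hydrogen in place of trifluoromethyl on an aromatic carbon. The change sits on the ring at the far end of the molecule, several bonds away from the amine chain that carries the proton. Compounds 1, 2 and 3 differ from one another at several points, yet their numbers all fall within the scatter, which suggests that the amine reading is not easily moved by changes elsewhere in the molecule.

The step from compound 2 to compound 4 is therefore expected to be small, a number 0.08 log units higher from compound 2 to compound 4 (within the scatter), possibly a slight rise but not clearly beyond the scatter. For compound 4 the estimate is 9.55, with a range from 9.2 to 9.9.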

Compound 4, acid dissociation constant: 9.47
Compound 4: the middle estimate sits 0.08 log units above what was measured, within the range that was stated.
By their numbers in this assay, from the lowest: compounds 1, 3, 2 and 4 (each within the scatter of the next).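

Among these compounds, the first pair in this set that differs in only one place shows that replacing trifluoromethyl with hydrogen on this aromatic carbon gives, in this assay, no change at the digits printed from compound 2 to compound 4 (within the scatter) and so isolates one change in a way the earlier compounds could not. Compounds 1, 2 and 3 differ at several points, so their similar numbers could not show what any single group contributes. Here, the change from 4-(trifluoromethyl)phenyl to phenyl removes four heavy atoms without moving the reading beyond the scatter, though no measurement accompanying this result explains why.

From the compounds shown here alone, this single pair speaks only for trifluoromethyl and hydrogen at this one position, so whether an amine or a carboxylic acid on the same aromatic carbon would also leave the reading within the scatter remains open. The shared three-carbon chain stays the same across the pair as well, which leaves open how a longer chain between the two amine nitrogens would read in this assay.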